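Pyridin-2-yl in Place of 2,3-Dichlorophenyl: An Expected Binding Number

The source may report more compounds than this note shows. Statements on the series, on what has been measured and on what is new or still open speak of the compounds shown alone.

For the measured compounds named here, compound 2 `O=C1c2ccccc2S(=O)(=O)N1CCCCCCN1CCN(c2cccc(Cl)c2Cl)CC1` gives 920 nM in an ADME assay on HEK293 cells for displacement of a labelled ligand from 5-hydroxytryptamine receptor 6 (Homo sapiens), read by radioligand binding, with a stated time of 1 h (on this read-out lower numbers stand for stronger inhibition and higher numbers for weaker inhibition), the higher of the two numbers measured so far. Going by the values given here, compound 1 `O=C1c2ccccc2S(=O)(=O)N1CCCCCCN1CCN(c2cccc(Cl)c2)CC1` gives 372 nM, and the single measured step, a 2.5-fold higher number from compound 1 to compound 2 (0.39 log units; beyond the scatter), is modest. Compound 3 `O=C1c2ccccc2S(=O)(=O)N1CCCCCCN1CCN(c2ccccn2)CC1` differs from compound 2 by pyridin-2-yl in place of 2,3-dichlorophenyl on an amine nitrogen in a ring. Among the compounds with values here, that measured step bears only in part: the chloro on the aromatic carbon that it added now leaves, together with the other chlorine, while the pyridin-2-yl that enters has no measured counterpart. A modest move back toward lower numbers is therefore expected for compound 3, a 1.5-fold lower number from compound 2 to compound 3 (0.19 log units; within the scatter), with wide uncertainty. Compound 3 is estimated at 600 nM, between 150 nM and 2500 nM.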

Compound 3, inhibition constant: 2350 nM
The estimate for compound 3 lay 3.9-fold (0.59 log units) below the measured number, within the range that was stated.
By their numbers in this assay, from the lowest: compound 1; then compound 2; then compound 3.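

On the amine nitrogen in a ring, pyridin-2-yl gives the highest number of the three in this assay: in place of 2,3-dichlorophenyl it brings a 2.6-fold higher number from compound 2 to compound 3 (0.41 log units; beyond the scatter), and in place of 3-chlorophenyl it brings a 6.3-fold higher number from compound 1 to compound 3 (0.80 log units; beyond the scatter). Thus both chlorinated phenyl groups stand at lower numbers than pyridin-2-yl, even though the second chlorine itself raises the number. Nothing measured here accounts for these steps. On these data alone, it remains open where an unsubstituted phenyl or a pyrimidin-2-yl on that nitrogen would fall, and whether a shorter chain would preserve this order.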